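Cytotoxicity of a methyl analogue in the difluorobenzyl pyrimidinone series

The compounds below may be only part of what the source reports. "The series", "measured", "known", "first", "only" and "open" are said of these compounds alone.

Three compounds from this series were examined in an ADME assay on MT4 cells (Homo sapiens) for cytotoxicity, read by MTT assay, with a stated time of 4 days; on this read-out higher numbers stand for lower toxicity in this test and lower numbers for higher toxicity in this test. Compound 1 `CC1CCCN(c2nc(Cc3c(F)cccc3F)cc(=O)[nH]2)C1` gave only a limit of the assay, > 78000 nM. Compound 2 `CC1CCN(c2nc(Cc3c(F)cccc3F)cc(=O)[nH]2)CC1` likewise gave only a limit, > 78000 nM. Compound 3 `O=c1cc(Cc2c(F)cccc2F)nc(-n2cccc2)[nH]1` also gave only a limit, > 87000 nM. Compound 2 therefore stands at a limit rather than at a number, and the two further values shown are limits as well, as told by the limit of > 78000 nM in this assay, at which 2 of the 3 values shown sit, and (the limit of > 87000 nM in this assay, at which 1 of the 3 values shown sits).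

Compound 4 `Cc1c(Cc2c(F)cccc2F)nc(N2CCC(C)CC2)[nH]c1=O` differs from compound 2 by methyl in place of hydrogen on an aromatic carbon. Among the compounds with values here, no measured step reaches this change directly. Within the data shown here, the steps that bear on the surroundings are a step that the two limits leave unreadable from compound 1 to compound 2, a step that the two limits leave unreadable from compound 1 to compound 3 and a step that the two limits leave unreadable from compound 2 to compound 3, none of which can be read in size because both ends of each sit at a limit.

Since every shown compound sits at a limit in this assay, no shift beyond the scatter is expected in this assay from the added methyl, and compound 4 is expected to be reported as a limit again. The expected step that the limit leaves unreadable from compound 2 to compound 4 is therefore estimated as none beyond the scatter. Compound 4 is estimated at 80000 nM, with a range from 40000 nM to 160000 nM.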

Compound 4, half-maximal cytotoxic concentration: > 75000 nM
Compound 4 was reported as a limit (the forecaster's own chance of this, stated with the estimate: 85%); the middle value is on the limit's open side.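

Compound 2 and compound 4 both stand at a limit in this assay, so the step between them cannot be read in size. The compounds shown leave open how far any of them lies past its limit, and so whether methyl in place of hydrogen on the aromatic carbon changes the read-out at all.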